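The compounds below may be only part of what the source reports. "The series", "measured", "known", "first", "only" and "open" are said of these compounds alone.

Working notes on the series, read-out an ADME assay on microsomes from liver (Rattus norvegicus) for metabolic stability, with a stated time of 30 min; a lower number here means that less of the compound is left, a higher number that more of the compound is left

compound 1 `CCCCNC(=O)c1cnc2c(c1)nc(NC(=O)c1cccc(C#N)c1)n2CCCOC` gives 73%
compound 2 `COCCCn1c(NC(=O)c2cccc(C#N)c2)nc2cc(C(=O)N3CCCCC3)ccc21` gives 16%
compound 3 `COCCCn1c(NC(=O)c2cccc(C#N)c2)nc2cc(C(=O)N3CCCCC3)cnc21` not yet measured

Compound 1 stands highest of the two measured compounds (at 73%), and compound 2 gives 16%. The gap between the two lies beyond the usual scatter.

The next step leads from compound 1 to compound 3, with piperidin-1-yl in place of butylamino on a carbonyl carbon. Among the measured compounds shown here, no pair of measured compounds differing in one place is available, so the size of this change in this assay has no direct measure. For the measured compounds named here, the only pointer is compound 2 (at 16%), which also carries piperidin-1-yl on a carbonyl carbon. That pointer is indirect, so a fall beyond the scatter is expected, but not one of the full gap between the two measured values. The expected change is a number 28 percentage points lower from compound 1 to compound 3 (beyond the scatter) in this estimate. For compound 3 the estimated value is 45% with an expected range from 20% to 72% (to be checked against the measurement).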

Compound 3, percent of the compound remaining: 36%
Estimate against measurement, compound 3: 9 percentage points above; measured number inside the range.
By their numbers in this assay, from the lowest: compound 2; then compound 3; then compound 1.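

In this assay, the series now has its first direct measure of a change on this carbonyl carbon: with piperidin-1-yl in place of butylamino, the result is a number 37 percentage points lower from compound 1 to compound 3 (beyond the scatter), so this position is sensitive to the group it carries. The step exchanges an open butyl chain bearing a hydrogen-bond donor for a six-membered non-aromatic ring without one, and this single pair cannot show which of these differences matters. No measurement at hand accounts for the fall.

The compounds shown leave open whether the ring or the missing amide hydrogen goes with the lower number, and a pair of groups on the same carbonyl carbon could separate the two: dimethylamino, which has no ring and no amide hydrogen, and cyclohexylamino, which has both a ring and the amide hydrogen. Also open, going by these compounds, is whether the step keeps its size on another core, and whether a ring with a further hetero atom, such as morpholin-4-yl, would read like piperidin-1-yl.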